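A Trifluoromethyl Substituent on the Aryl Ring of Compound 3

This account rests on a few compounds, and the source may have more. Where it says the series, first, only, none or still open, it means among the compounds named here.

The set comprises three measured compounds. Compound 1 `O=C1N(c2cccc(Cl)c2)CCN1C1CN2CCC1CC2` gives 30.9 nM in a functional assay (Cavia porcellus) for antagonist activity at Serotonin 3 (5-HT3) receptor (Homo sapiens); a lower number here means a stronger inhibitor, a higher number a weaker inhibitor. Compound 2 `O=C1N(c2cccc([N+](=O)[O-])c2)CCN1C1CN2CCC1CC2` gives 75.2 nM in this assay. For the measured compounds named here, the step of a 2.4-fold higher number from compound 1 to compound 2 (0.39 log units; beyond the scatter) is the only single-point change measured here. Compound 3 `Cc1[nH]cnc1CN1CCN(c2ccccc2)C1=O`, built on a different core, gives 26.9 nM in this assay; its number lies within the scatter of compound 1 and beyond the scatter of compound 2.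

Compound 4 `Cc1[nH]cnc1CN1CCN(c2cccc(C(F)(F)F)c2)C1=O` differs from compound 3 by trifluoromethyl in place of hydrogen on an aromatic carbon. Going by the values given here, no measured step involves a trifluoromethyl group, and the one step available, nitro in place of chloro, concerns a different core and a different pair of groups, so it offers only a loose guide: a single substituent change on the aromatic ring there moved the number modestly. The expected step is a 1.1-fold higher number from compound 3 to compound 4 (0.05 log units; within the scatter), which need not exceed the scatter. The estimate for compound 4 is 30 nM, spanning 10 nM to 90 nM.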

Compound 4, antagonist equilibrium constant: 68.5 nM
Estimate against measurement, compound 4: 2.3-fold (0.36 log units) below; the measured number falls inside the stated range.
By their numbers in this assay, from the lowest: compounds 3 and 1 (each within the scatter of the next); then compounds 4 and 2 (each within the scatter of the next).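

On the core of compound 3, trifluoromethyl on an aromatic carbon, meta to a large group, gives a 2.5-fold higher number from compound 3 to compound 4 (0.41 log units; beyond the scatter) in this assay, the first measured sign that this position on that core responds to substitution. The earlier step, a 2.4-fold higher number from compound 1 to compound 2 (0.39 log units; beyond the scatter), exchanged one substituent for another on a different core, whereas this one starts from the bare ring and shows that adding a group here moves the number upward. Nothing available bears on why the number rose.

Going by these compounds, whether this rise belongs to trifluoromethyl itself or would follow any group at this place stays open, and a methoxy group or an amine on the same carbon of compound 3 would help separate the two. The compounds shown also leave open how the other carbons of this aromatic ring respond to substitution.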